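Five-membered ring swap at the aromatic carbon of compound 2

The source may hold more compounds than are shown below. What is called first, only, known or untested is meant among the compounds shown, and "the series" means these compounds.

In an ADME assay on MT4 cells (Homo sapiens) for cytotoxicity, read by MTT assay, with a stated time of 5 days (a lower number here means that less compound is tolerated, a higher number that more compound is tolerated), the measured values are as follows:
- compound 1 `Cc1cc(C)cc(-c2cnc(Nc3ccc(C#N)cc3)nc2Oc2c(C)cc(C#N)cc2C)c1` gives 39000 nM
- compound 2 `Cc1ccc(-c2cnc(Nc3ccc(C#N)cc3)nc2Oc2c(C)cc(C#N)cc2C)cc1` gives 26100 nM
- compound 3 `Cc1cc(C#N)cc(C)c1Oc1nc(Nc2ccc(C#N)cc2)ncc1-c1ccco1` gives > 306000 nM as a limit of the assay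

Within the data shown here, compound 2 sits level with its one numeric neighbour, with a 1.5-fold lower number from compound 1 to compound 2 (0.17 log units; within the scatter) as the step between them. The change to compound 4 `Cc1cc(C#N)cc(C)c1Oc1nc(Nc2ccc(C#N)cc2)ncc1-c1ccsc1` puts thiophen-3-yl in place of 4-methylphenyl on an aromatic carbon. The closest measured step is an at least 11-fold higher number from compound 2 to compound 3 (1.06 log units; beyond the scatter) for furan-2-yl at the same place, and an at least 7.8-fold higher number from compound 1 to compound 3 (0.89 log units; beyond the scatter) points the same way. Going by these compounds, both steps rest on the limit of compound 3, so their full size stays open. Among the measured compounds shown here, only one five-membered ring has been measured here and thiophen-3-yl is a different group, so only part of that rise is expected to carry over. In this assay the expected change is a 3.1-fold higher number from compound 2 to compound 4 (0.49 log units; beyond the scatter) with wide margins. For compound 4 the estimated value is 80000 nM with an expected range from 25000 nM to 300000 nM in this series.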

Compound 4, half-maximal cytotoxic concentration: 3920 nM
Compound 4: the middle estimate sits 20-fold (1.31 log units) above what was measured, outside the stated range (below it).
By their numbers in this assay, from the lowest: compound 4; then compounds 2 and 1 (each within the scatter of the next). At a limit, above all of these: compound 3.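

At this aromatic carbon, a five-membered ring does not by itself raise the number in this assay: thiophen-3-yl gives a 6.7-fold lower number from compound 2 to compound 4 (0.82 log units; beyond the scatter) and a 9.9-fold lower number from compound 1 to compound 4 (1.00 log units; beyond the scatter), so compound 4 goes against the rise seen with compound 3. The two five-membered rings also lie far apart, with an at least 78-fold lower number from compound 3 to compound 4 (1.89 log units; beyond the scatter), which ties the high number to furan-2-yl rather than to ring size alone. The full size of that gap stays open, as compound 3 stands at a limit and not at a number: the limit of > 306000 nM in this assay, at which 1 of the 4 values shown sits.

Furan-2-yl and thiophen-3-yl differ in both the hetero atom and the point of attachment, so the compounds shown cannot separate the two. Thiophen-2-yl and furan-3-yl at this carbon would do so, and how a pyridin-3-yl ring would behave here also remains open.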